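A selenium group replaces the propyl chain of compound 1

The source may hold more compounds than are shown below. What is called first, only, known or untested is meant among the compounds shown, and "the series" means these compounds.

Measured compounds:
compound 1 `CCCCC(=O)N(Cc1ccc(OC)c(O)c1)c1cc(OC)c(OC)c(OC)c1` — 300 nM
compound 2 `C/C=C/C(=O)N(Cc1ccc(OC)c(OC)c1)c1cc(OC)c(OC)c(OC)c1` — 39100 nM
compound 3 `C/C=C/C(=O)N(Cc1ccc(OC)c(C)c1)c1cc(OC)c(OC)c(OC)c1` — 32900 nM

In a functional assay on KYSE-450 cells (Homo sapiens) for inhibition, read by MTT assay, with a stated time of 48 h (on this read-out higher numbers stand for weaker inhibition and lower numbers for stronger inhibition), compound 1 gives 300 nM, the lowest of the three numbers. Compound 3 gives 32900 nM and compound 2 gives 39100 nM; both gaps from compound 1 lie well beyond the scatter, but each of these compounds differs from compound 1 in more than one place, so no single step is drawn from them. Among the compounds with values here, the one step between compounds that differ in a single place is a 1.2-fold lower number from compound 2 to compound 3 (0.07 log units; within the scatter), a methyl in place of a methoxy on an aromatic carbon, which changes the number by an amount within the scatter.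

Compound 4 `COc1ccc(CN(C(=O)C[Se]C#N)c2cc(OC)c(OC)c(OC)c2)cc1O` is made from compound 1 by the change (a group of 3 heavy atoms (1 carbon, 1 nitrogen, 1 selenium; no ring) in place of a group of 3 heavy atoms (3 carbon; no ring), on a saturated chain carbon bound to a carbonyl carbon). Within the data shown here, no measured step concerns this chain position; the one step known touches an aromatic substituent and says nothing about the group bound to the carbonyl carbon. The expectation for compound 4 therefore rests on compound 1 alone, whose 300 nM is the starting point, and the step of a 1.3-fold higher number from compound 1 to compound 4 (0.12 log units; within the scatter) is expected to be small. Compound 4 is estimated at 400 nM, within a wide range from 60 nM to 3000 nM.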

Compound 4, half-maximal inhibitory concentration: 280 nM
Compound 4: the middle estimate sits 1.4-fold (0.15 log units) above what was measured; low and high end bracket the measured number.
By their numbers in this assay, from the lowest: compounds 4 and 1 (each within the scatter of the next); then compounds 3 and 2 (each within the scatter of the next).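

In this assay, the saturated chain carbon bound to a carbonyl carbon accepts a group of 1 carbon, 1 nitrogen and 1 selenium in place of the propyl, with a 1.1-fold lower number from compound 1 to compound 4 (0.03 log units; within the scatter). Within the data shown here, until now the only step known concerned an aromatic substituent, so nothing measured spoke for this chain position. It now has one step, which stays within the scatter even though the entering group differs from the propyl in its atoms and brings 1 triple bond outside aromatic rings and 1 hydrogen-bond acceptor. No measurement accompanies these numbers that could account for how closely the two groups read.

The compounds shown leave open how an amine, a carboxylic acid or a longer chain on this carbon would read in this assay. They also leave open whether the selenium or the nitrile carries the result, a question on which a thiocyanate group, with sulfur in place of selenium, or a plain methylselenyl group would bear.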